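Sulfonyl substituent change on the shared core

This account rests on a few compounds, and the source may have more. Where it says the series, first, only, none or still open, it means among the compounds named here.

Compound 1 `O=C(Nc1cccc(S(=O)(=O)C2CCCC2)n1)c1ccc(NCCO)cc1N1CCC2(CC1)CC2`: 177 nM
Compound 2 `O=C(Nc1cccc(S(=O)(=O)N2CCCC2)c1)c1cccnc1N1CCC2(CC1)CC2`: 5460 nM
Compound 3 `CC(C)(C)NS(=O)(=O)c1cccc(NC(=O)c2ncc(NS(C)(=O)=O)nc2N2CCC3(CC2)CC3)n1`: 32 nM

In a functional assay on OVCAR-3 cells (Homo sapiens) for activation, with a stated time of 24 h (a lower number here means that less compound is needed, a higher number that more compound is needed for the effect), compound 2 holds the highest number of the three; compound 1 lies below it beyond the scatter, and compound 3 further below still. Compound 4 `CC(C)(CO)S(=O)(=O)c1cccc(NC(=O)c2cccnc2N2CCC3(CC2)CC3)c1` has not yet been measured in this assay. It differs from compound 2 in one place: 1-(hydroxymethyl)-1-methylethyl in place of pyrrolidin-1-yl on a sulfonyl sulfur. Among the measured compounds shown here, compounds 1 and 3 carry other groups on their sulfonyl sulfur and both give lower numbers than compound 2, but neither differs from compound 2 in this place alone, so no direct step is available. A moderate lowering is expected, a 3.6-fold lower number from compound 2 to compound 4 (0.56 log units; beyond the scatter), resting on the lower numbers of compounds 1 and 3 only. Compound 4 is estimated at 1500 nM, with a range from 400 nM to 6000 nM.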

Compound 4, half-maximal effective concentration: 45900 nM
For compound 4 the middle estimate is 31-fold (1.49 log units) below the measured one, outside the stated range (above it).
By their numbers in this assay, from the lowest: compound 3; then compound 1; then compound 2; then compound 4.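

In this assay, among the compounds shown here, the sulfonyl sulfur of compound 2 responds to a single exchange: 1-(hydroxymethyl)-1-methylethyl in place of pyrrolidin-1-yl gives an 8.4-fold higher number from compound 2 to compound 4 (0.92 log units; beyond the scatter) and is the only direct step at this place. The entering group has as many heavy atoms as pyrrolidin-1-yl, so heavy-atom count alone does not preserve the number here. Nothing available explains this step.

Going by these compounds, it remains open whether the higher number follows the hydroxyl or the absence of a ring. A plain tert-butyl group on the sulfonyl sulfur would separate the two.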